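The source may report more compounds than this note shows. Statements on the series, on what has been measured and on what is new or still open speak of the compounds shown alone.

The measured compounds and their values:

Compound 1, `O=C(CSc1nc2c(c(=O)n1-c1ccccc1)SCC2)Nc1ccc(N2CCCCC2)cc1`: 30 nM
Compound 2, `O=C(CSc1nc2c(c(=O)n1-c1ccccc1)SCC2)Nc1ccc(-c2ccccc2)cc1`: 0.75 nM
Compound 3, `CC(=O)c1ccc(NC(=O)CSc2nc3c(c(=O)n2-c2ccccc2)SCC3)cc1`: > 1000 nM

All three were tested in an assay on L cells for inhibition of Protein-serine O-palmitoleoyltransferase porcupine (Mus musculus), read by reporter gene assay, with a stated time of 24 h; a lower number here means that less compound is needed, a higher number that more compound is needed for the effect. Compound 2 gives the lowest number in this assay, at 0.75 nM, while compound 1 gives 30 nM. For compound 3 the result is only a limit of the assay, (the limit of > 1000 nM in this assay, at which 1 of the 3 values shown sits), so its exact value is not known; it stands at the weak end of the three. The steps show this clearly: an at least 33-fold higher number from compound 1 to compound 3 (1.52 log units; beyond the scatter) and an at least 1300-fold higher number from compound 2 to compound 3 (3.12 log units; beyond the scatter). The step between compounds 1 and 2 is also large, a 40-fold lower number from compound 1 to compound 2 (1.60 log units; beyond the scatter).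

Compound 4, `O=C(CSc1nc2c(c(=O)n1-c1ccccc1)SCC2)Nc1ccc(-c2cccnc2)cc1`, has not yet been measured in this assay. It differs from compound 3 in one place: pyridin-3-yl in place of acetyl on an aromatic carbon. The change runs against the direction of the acetyl steps, and pyridin-3-yl resembles the phenyl of compound 2, so a large drop in the number is expected, well beyond the scatter. The step from compound 3 to compound 4 is estimated at an at least 400-fold lower number from compound 3 to compound 4 (2.60 log units; beyond the scatter). Compound 4 is expected to give about 2.5 nM in this assay, with a range from 0.5 nM to 15 nM.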

Compound 4, half-maximal effective concentration: 0.45 nM
Compound 4: middle estimate off by 5.6-fold (0.74 log units), on the high side, and the stated range ends above it.
By their numbers in this assay, from the lowest: compounds 4 and 2 (each within the scatter of the next); then compound 1. At a limit, above all of these: compound 3.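

In this assay, the new result shows that a ring nitrogen is accepted in the aromatic ring at this place, as pyridin-3-yl and phenyl give a 1.7-fold lower number from compound 2 to compound 4 (0.22 log units; within the scatter). Pyridin-3-yl also keeps the large gap to the other two groups, with a 67-fold lower number from compound 1 to compound 4 (1.82 log units; beyond the scatter) against piperidin-1-yl and an at least 2200-fold lower number from compound 3 to compound 4 (3.34 log units; beyond the scatter) against acetyl. The size of that last step rests on compound 3, whose value is only a limit: the limit of > 1000 nM in this assay, at which 1 of the 4 values shown sits.

The compounds shown leave open whether a pyridin-4-yl, a morpholin-4-yl or an outer ring carrying a carboxylic acid or an amine would stay in the range of compound 2 and compound 4. All the changes shown lie at this one place, so they say nothing about changes elsewhere on the shared core.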